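This account rests on a few compounds, and the source may have more. Where it says the series, first, only, none or still open, it means among the compounds named here.

Measured in a functional assay on HCT-116 cells (Homo sapiens) for cytotoxicity, read by MTT assay, with a stated time of 48 h; a lower number here means a stronger inhibitor, a higher number a weaker inhibitor:
compound 1 `CNC(=O)c1cc(Oc2cccc(NC(=S)Nc3ccc(Cl)cc3)c2)ccn1`: 39400 nM
compound 2 `O=C(c1cc(Oc2cccc(NC(=S)Nc3cccc(C(F)(F)F)c3)c2)ccn1)N1CCCC1`: 19200 nM
compound 3 `CNC(=O)c1cc(Oc2cccc(NC(=S)Nc3ccc(OC(F)(F)F)cc3)c2)ccn1`: 33800 nM

Compound 3 holds the second highest of the three numbers; its value sits within the scatter of compound 1 and of compound 2, so no ordering among the three is claimed. For the measured compounds named here, the one step measured in one place, a 1.2-fold lower number from compound 1 to compound 3 (0.07 log units; within the scatter), changes the aryl substituent and does not touch the amide.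

Compound 4 `O=C(c1cc(Oc2cccc(NC(=S)Nc3ccc(OC(F)(F)F)cc3)c2)ccn1)N1CCCC1` differs from compound 3 by pyrrolidin-1-yl in place of methylamino on a carbonyl carbon. Going by the values given here, no measured step isolates this change. Compound 2 carries the same pyrrolidinyl amide with a different aryl group, and its value lies within the scatter of the value of compound 3. The step to compound 4 is therefore expected to stay within the scatter, estimated as a 1.5-fold lower number from compound 3 to compound 4 (0.19 log units; within the scatter). Compound 4 is expected to give about 22000 nM in this assay, ranging from 8000 nM to 60000 nM.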

Compound 4, half-maximal inhibitory concentration: 17800 nM
Compound 4: the middle estimate sits 1.2-fold (0.09 log units) above what was measured; the range from low to high includes it.
By their numbers in this assay, from the lowest: compounds 4, 2, 3 and 1 (each within the scatter of the next, the first and the last beyond it).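

In this assay, for the compounds shown here, the step of a 1.9-fold lower number from compound 3 to compound 4 (0.28 log units; within the scatter) is the first direct reading of pyrrolidin-1-yl in place of methylamino on a carbonyl carbon, and the numbers do not separate the two amides. With the pyrrolidinyl amide held fixed, the step of a 1.1-fold lower number from compound 2 to compound 4 (0.03 log units; within the scatter) leaves 4-(trifluoromethoxy)phenyl and 3-(trifluoromethyl)phenyl on an amide-type nitrogen equally unseparated. Nothing available explains either step.

Open, as far as these compounds go, is whether a carboxylic acid, a piperazine or a longer chain on this carbonyl carbon would give a step beyond the scatter. The pyrrolidinyl amide is also untested with the 4-chlorophenyl group of compound 1.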